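Pyridin-4-yl in place of pyridin-2-yl: working notes

The source may report more compounds than this note shows. Statements on the series, on what has been measured and on what is new or still open speak of the compounds shown alone.

Measured in a functional assay on HL-60 cells (Homo sapiens) for cytotoxicity, read by ELISA, with a stated time of 2 days (a lower number here means a stronger inhibitor, a higher number a weaker inhibitor), so far
- compound 1 `Oc1cccc(-c2cc(-c3ccccc3)nc(-c3ccccc3)c2)c1` gives 13500 nM
- compound 2 `Oc1cccc(-c2cc(-c3ccccc3)nc(-c3ccco3)c2)c1` gives 24000 nM
- compound 3 `Oc1cccc(-c2cc(-c3ccccc3)nc(-c3ccccn3)c2)c1` gives 15100 nM

Compound 3 cannot be told apart from the other two compounds on these numbers. Its two steps are a 1.1-fold higher number from compound 1 to compound 3 (0.05 log units; within the scatter) and a 1.6-fold lower number from compound 2 to compound 3 (0.20 log units; within the scatter) and neither goes beyond the scatter. The remaining step is a 1.8-fold higher number from compound 1 to compound 2 (0.25 log units; within the scatter) and it also stays inside the scatter.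

The next compound is compound 4 `Oc1cccc(-c2cc(-c3ccccc3)nc(-c3ccncc3)c2)c1` and the change is pyridin-4-yl in place of pyridin-2-yl on an aromatic carbon with the same atoms joined differently. It puts pyridin-4-yl in place of pyridin-2-yl on an aromatic carbon, next to the ring nitrogen.

All three measured steps concern this same place, and none of them involves pyridin-4-yl, so the inference is limited to these compounds. Among the measured compounds shown here, the closest precedent is a 1.1-fold higher number from compound 1 to compound 3 (0.05 log units; within the scatter) as a change of ring at this place. No step beyond the scatter is expected, in either direction.

The expected step is a 1.1-fold higher number from compound 3 to compound 4 (0.03 log units; within the scatter) and it stays within the scatter. Compound 4 is estimated at 16000 nM with an expected range of 8000 nM to 30000 nM in this assay pending measurement.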

Compound 4, half-maximal inhibitory concentration: 12700 nM
The estimate for compound 4 lay 1.3-fold (0.10 log units) above the measured number; the measured number falls inside the stated range.
By their numbers in this assay, from the lowest: compounds 4, 1, 3 and 2 (each within the scatter of the next).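

In this assay the step with pyridin-4-yl in place of pyridin-2-yl is a 1.2-fold lower number from compound 3 to compound 4 (0.08 log units; within the scatter) and stays inside the scatter, so at this place the two pyridine isomers, with the same atoms joined differently, cannot be told apart. Pyridin-4-yl reads the same against the other two rings, with a 1.1-fold lower number from compound 1 to compound 4 (0.03 log units; within the scatter) against phenyl and a 1.9-fold lower number from compound 2 to compound 4 (0.28 log units; within the scatter) against furan-2-yl, so all four aromatic rings at this place now lie within the scatter of one another. No measurement at hand offers an explanation for this flat reading.

Still open, on these data alone, is whether any group at this place can carry the number beyond the scatter, in either direction. As far as these compounds go, an amine, a carboxylic acid or a longer alkyl chain in place of the ring would test that, and the 3-hydroxyphenyl group and the remaining phenyl group stay unexplored here.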